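Nitro in place of trifluoromethyl: compound 3 to compound 4

A few compounds are considered here, and "the series" means these few. Any claim that something is new, unique, unknown or untested is made for them only; others in the source may bear on it.

Values in a functional assay on A549 cells (Homo sapiens) for antiproliferative activity, read by MTT assay, with a stated time of 72 h; a lower number here means a stronger inhibitor, a higher number a weaker inhibitor:
- compound 1 `Nc1ccccc1NC(=O)CCCCCCc1nc(-c2ccc([N+](=O)[O-])cc2)no1`: > 100000 nM (a limit)
- compound 2 `O=C(CCCCCCc1nc(-c2ccccc2)no1)C(F)(F)F`: 7680 nM
- compound 3 `O=C(CCCCCCc1nc(-c2ccc(C(F)(F)F)cc2)no1)C(F)(F)F`: 28800 nM
- compound 4 `O=C(CCCCCCc1nc(-c2ccc([N+](=O)[O-])cc2)no1)C(F)(F)F`: not yet measured

In this assay compound 3 stands at 28800 nM, the higher of the two true numbers, and its nearest neighbour is compound 2 at 7680 nM. The next change is nitro in place of trifluoromethyl on an aromatic carbon, para to a large group: nitro in place of trifluoromethyl on an aromatic carbon. Among the compounds with values here, the one measured step that bears on this carbon is modest: a 3.8-fold higher number from compound 2 to compound 3 (0.57 log units; beyond the scatter). That step replaces hydrogen, not nitro, so it gives only a rough scale. Compound 1 also carries nitro, but its other end differs. For compound 1, > 100000 nM is a limit and not a number, so it gives no step size. Given the modest size of a 3.8-fold higher number from compound 2 to compound 3 (0.57 log units; beyond the scatter), only a small change is expected, with a slight lean towards a lower number and no firm direction. The expected change is a 1.4-fold lower number from compound 3 to compound 4 (0.16 log units; within the scatter). Compound 4 is estimated at 20000 nM, with an expected range of 7000 nM to 60000 nM.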

Compound 4, half-maximal inhibitory concentration: > 100000 nM
Compound 4: a limit, no number; the forecaster's own chance of this, stated with the estimate: 8%; middle value at least 5.0-fold (0.69 log units) away from the limit.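

In this assay, nitro in place of trifluoromethyl on this aromatic carbon, para to a large group, gives an at least 3.4-fold higher number from compound 3 to compound 4 (0.54 log units; beyond the scatter), so the two groups are not interchangeable at this position. Against hydrogen, nitro gives an at least 13-fold higher number from compound 2 to compound 4 (1.11 log units; beyond the scatter), a large step beside the modest 3.8-fold higher number from compound 2 to compound 3 (0.57 log units; beyond the scatter), so both groups go with a higher number than hydrogen, nitro by the wider margin. Compound 4 sits at a limit shared with compound 1, and the step between these two cannot be read: the limit of > 100000 nM in this assay, at which 2 of the 4 values shown sit.

Going by these compounds, how an amine or a methoxy group on this aromatic carbon would read in this assay stays open. Also open, on these data alone, is the true size of the nitro steps, and how a carboxylic acid on the carbonyl carbon would read alongside nitro.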